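This account rests on a few compounds, and the source may have more. Where it says the series, first, only, none or still open, it means among the compounds named here.

In an ADME assay on Raji cells (Homo sapiens) for cytotoxicity, read by luminescence, with a stated time of 72 h (on this read-out lower numbers stand for an effect already at smaller amounts and higher numbers for an effect only at larger amounts of compound), compound 1 (`CCOC(=O)c1c(-c2cccc(OCC)c2)[nH]c2cc(OC)ccc2c1=O`) gives > 21500 nM, which is a limit of the assay and not a number. Compound 2 (`CCCOc1cccc(-c2[nH]c3cc(OC)ccc3c(=O)c2C(=O)OCC)c1`) gives > 21500 nM, and this too is a limit. Among the compounds with values here, compound 2 therefore has no exact position on the scale, and the only evidence so far is the limit of > 21500 nM in this assay, at which 2 of the 2 values shown sit. Within the data shown here, the one measured step that bears on the next change is a step that the two limits leave unreadable from compound 1 to compound 2, which places methyl in place of hydrogen on a saturated chain carbon, two bonds along the chain from an oxygen on an aromatic ring. Its size cannot be carried forward. Compound 3 (`CCOC(=O)c1c(-c2cccc(OC(C)C)c2)[nH]c2cc(OC)ccc2c1=O`) has the same atoms as compound 2, joined differently, with propoxy changed to isopropoxy: isopropyl in place of propyl on an oxygen on an aromatic ring. This places isopropyl in place of propyl on an oxygen on an aromatic ring. No step beyond the usual scatter is expected in this assay, and no direction can be stated. The expected step is a step that the limit leaves unreadable from compound 2 to compound 3. Compound 3 is estimated at 25000 nM, with an expected range from 12000 nM to 50000 nM.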

Compound 3, half-maximal effective concentration: > 21500 nM
Compound 3: no number, only a limit; the forecaster's own chance of this, stated with the estimate: 85%; the middle value lies beyond the limit too.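

In this assay compound 3 gives > 21500 nM, which is a limit of the assay and not a number. Within the data shown here, the steps among compound 1, compound 2 and compound 3 cannot be read, so no new step emerges. The compounds shown leave open where any of the three stands on the scale, and whether isopropyl in place of propyl changes anything: the limit of > 21500 nM in this assay, at which 3 of the 3 values shown sit.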